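Swapping the aryl group on the shared core: a fluorophenyl variant

The source may hold more compounds than are shown below. What is called first, only, known or untested is meant among the compounds shown, and "the series" means these compounds.

Measured compounds in a functional assay on EBC-1 cells (Homo sapiens) for antiproliferative activity, with a stated time of 72 h; a lower number here means a stronger inhibitor, a higher number a weaker inhibitor:
compound 1 `COc1ccc2c(OCc3nnc4sc(-c5ccc[nH]5)nn34)ccnc2c1` gives 313 nM
compound 2 `COc1ccc2c(OCc3nnc4sc(-c5cc6ccccc6n5C)nn34)ccnc2c1` gives 149 nM
compound 3 `COc1ccc2c(OCc3nnc4sc(-c5ccncc5)nn34)ccnc2c1` gives 289 nM

All three compounds share one core and differ only in the aromatic group attached to it. Compound 3 sits second highest of the three numbers; its nearest neighbour is compound 1, and the gap between them is within the scatter, as is the gap to compound 2, so no order among these three can be claimed.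

Compound 4 `COc1ccc2c(OCc3nnc4sc(-c5cccc(F)c5)nn34)ccnc2c1` is not yet measured. It differs from compound 3 by 3-fluorophenyl in place of pyridin-4-yl on an aromatic carbon.

Three measured steps exchange the group at this same place: a 2.1-fold lower number from compound 1 to compound 2 (0.32 log units; beyond the scatter), a 1.1-fold lower number from compound 1 to compound 3 (0.03 log units; within the scatter) and a 1.9-fold higher number from compound 2 to compound 3 (0.29 log units; within the scatter). Only one of them moves beyond the scatter, and that one is modest. Among the measured compounds shown here, no measured step involves a fluorophenyl group, so the change to compound 4 has no direct precedent. The expectation is therefore a step of no clear direction, a 1.2-fold lower number from compound 3 to compound 4 (0.06 log units; within the scatter), staying within the scatter. Compound 4 is estimated at 250 nM, with a likely range from 90 nM to 700 nM.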

Compound 4, half-maximal inhibitory concentration: 504 nM
Compound 4: the middle estimate sits 2.0-fold (0.30 log units) below what was measured, within the range that was stated.
By their numbers in this assay, from the lowest: compounds 2, 3, 1 and 4 (each within the scatter of the next, the first and the last beyond it).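

In this assay, the position takes 3-fluorophenyl, a ring of carbon only, with a 1.7-fold higher number from compound 3 to compound 4 (0.24 log units; within the scatter) and a 1.6-fold higher number from compound 1 to compound 4 (0.21 log units; within the scatter), so replacing pyridin-4-yl or 1H-pyrrol-2-yl with this ring gives no change that can be told from the scatter. Among the compounds shown here, the only new step beyond the scatter is a modest one, a 3.4-fold higher number from compound 2 to compound 4 (0.53 log units; beyond the scatter), which leaves compound 2 clearly apart from compound 1 and compound 4 but not from compound 3. No measurement shown here accounts for these differences.

The compounds shown leave open whether the fluorine matters at all, which plain phenyl would test. They also leave open how a non-aromatic group at this position, such as morpholine or a short alkyl chain, would compare.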